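The source may hold more compounds than are shown below. What is called first, only, known or untested is meant among the compounds shown, and "the series" means these compounds.

Compound 1 `COc1ccccc1OCc1cc(C)nc(-c2ccccn2)n1`: 2000 nM in a functional assay on cells for antagonist activity at Free fatty acid receptor 1 (Homo sapiens), read by TR-FRET and inositol phosphate accumulation, with a stated time of 2 h; on this read-out lower numbers stand for stronger inhibition and higher numbers for weaker inhibition
Compound 2 `Cc1cc(COc2ccccc2C#N)nc(-c2ccccn2)n1`: 10000 nM
Compound 3 `CC(=O)Nc1ccccc1OCc1cc(C)nc(-c2ccccn2)n1`: > 39800 nM, a limit of the assay

Compound 3 stands weakest of the three on this assay, and its value is a limit rather than a number because of the limit of > 39800 nM in this assay, at which 1 of the 3 values shown sits. The step to compound 4 `Cc1cc(COc2ccccc2S(C)(=O)=O)nc(-c2ccccn2)n1` is methylsulfonyl in place of acetamido on an aromatic carbon. Two measured steps end at the acetamido group: an at least 19-fold higher number from compound 1 to compound 3 (1.29 log units; beyond the scatter) and an at least 3.9-fold higher number from compound 2 to compound 3 (0.59 log units; beyond the scatter). Both went beyond the scatter toward weaker inhibition, and both replaced a group with no hydrogen-bond donor by acetamido. Methylsulfonyl likewise carries no donor, so given an at least 19-fold higher number from compound 1 to compound 3 (1.29 log units; beyond the scatter) and an at least 3.9-fold higher number from compound 2 to compound 3 (0.59 log units; beyond the scatter) a return toward stronger inhibition is expected, an at least 4.9-fold lower number from compound 3 to compound 4 (0.69 log units; beyond the scatter). Compound 4 is estimated at 8000 nM, within 2000 nM to 39800 nM.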

Compound 4, half-maximal inhibitory concentration in the Free fatty acid receptor 1 assay: > 39800 nM
Compound 4: no number, only a limit (the forecaster's own chance of this, stated with the estimate: 30%); middle value at least 4.9-fold (0.69 log units) from the limit.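

In the Free fatty acid receptor 1 assay compound 4 gives > 39800 nM, which is a limit of the assay and not a number. In the Free fatty acid receptor 1 assay, methylsulfonyl on this aromatic carbon gives an at least 3.9-fold higher number from compound 2 to compound 4 (0.59 log units; beyond the scatter) and an at least 19-fold higher number from compound 1 to compound 4 (1.29 log units; beyond the scatter), so having no hydrogen-bond donor does not by itself keep a readable value at this position. Compound 3 and compound 4 both sit at a limit, so the step between them cannot be read: the limit of > 39800 nM in the Free fatty acid receptor 1 assay, at which 2 of the 4 values shown sit. In a physicochemical assay for lipophilicity, at pH 7.4 (on this read-out higher numbers stand for higher lipophilicity and lower numbers for lower lipophilicity), compound 3 gives 1.6 and compound 4 gives 1.5, and the same change gives a number 0.10 log units lower from compound 3 to compound 4 (within the scatter).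

Among the groups shown, only methoxy and nitrile give numbers. On these data alone, whether a chlorine atom, a hydroxyl group or an amine here would give a number in the Free fatty acid receptor 1 assay stays open.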